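This account rests on a few compounds, and the source may have more. Where it says the series, first, only, none or still open, it means among the compounds named here.

The compounds are compared in a functional assay on NCI-H460 cells (Homo sapiens) for cytotoxicity, read by MTT assay, with a stated time of 72 h; a higher number here means a weaker inhibitor, a lower number a stronger inhibitor. Compound 1 `CCN(CC)CCCNc1nc(-c2ccc(NC(=O)Nc3ccccc3Cl)cc2)nc2c(Cl)c(Cl)sc12` gives 330 nM there. Compound 2 `CCN(CC)CCCNc1nc(-c2ccc(NC(=O)Nc3ccccc3Cl)cc2)nc2ccsc12` carries a different core; how the two cores differ is not broken down here. In this assay compound 2 gives 200 nM, a number that sits within the scatter of the value of compound 1. Compound 3 `CCN(CC)CCCNc1nc(-c2ccc(NC(=O)Nc3ccc(C)cc3)cc2)nc2c(Cl)c(Cl)sc12` shares the core of compound 1 and differs from it in one place: 4-methylphenyl in place of 2-chlorophenyl on an amide-type nitrogen. In this assay compound 3 gives 1240 nM, so the step is a 3.8-fold higher number from compound 1 to compound 3 (0.57 log units; beyond the scatter).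

Compound 4 `CCN(CC)CCCNc1nc(-c2ccc(NC(=O)Nc3ccc(C)cc3)cc2)nc2ccsc12` is the unmeasured member. It stands to compound 2 as compound 3 stands to compound 1: 4-methylphenyl in place of 2-chlorophenyl on an amide-type nitrogen. The place of the change reads the same in both pairs, an amide-type nitrogen whose other neighbour is a carbonyl carbon, so this is the same change, applied to the core of compound 2. The expectation for compound 4 rests on two things. The change itself has one precedent, and that precedent moved the number beyond the scatter because a 3.8-fold higher number from compound 1 to compound 3 (0.57 log units; beyond the scatter) was measured directly. The two cores, meanwhile, gave close numbers, since compound 1 gave 330 nM and compound 2 gave 200 nM. A step of about the same size is therefore expected, namely a 3.6-fold higher number from compound 2 to compound 4 (0.56 log units; beyond the scatter). Compound 4 is accordingly estimated at 720 nM, with the likely range running from 320 nM to 1600 nM.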

Compound 4, half-maximal inhibitory concentration: 1240 nM
Beside the measured number, compound 4's estimate is 1.7-fold (0.24 log units) below it; the range from low to high includes it.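

In this assay, replacing 2-chlorophenyl with 4-methylphenyl on an amide-type nitrogen, this time on the core of compound 2, gives a 6.2-fold higher number from compound 2 to compound 4 (0.79 log units; beyond the scatter), so the number rises on this core as it did on the core of compound 1. Set side by side, the two steps point the same way and cannot be told apart in size: the same change on two cores in this assay, a 3.8-fold higher number (0.57 log units; beyond the scatter) from compound 1 to compound 3 and a 6.2-fold higher number (0.79 log units; beyond the scatter) from compound 2 to compound 4, 1.7-fold (0.22 log units) apart, within the scatter of two such steps. Within the data shown here, this shows that, for these two cores, the change carried over with its direction kept and its size within the scatter, but it rests on only two pairs and does not show that the step would hold on any other core, nor does it explain why the number rises.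

The change also replaces the chlorine with a methyl group and alters the numbered place of the substituent at once, so the compounds shown leave open which of these matters; 2-methylphenyl and 4-chlorophenyl on either core would separate the two. They also leave open whether the step survives with a morpholine in place of the diethylamino end of the side chain, or with a shorter chain linking that amine to the core.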